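The source may report more compounds than this note shows. Statements on the series, on what has been measured and on what is new or still open speak of the compounds shown alone.

Compound 1, `CCOC(=O)c1ccc(-c2nn(Cc3cccc(Cl)c3)c3ccccc23)cc1`. In a functional assay on cells (Platelet, Homo sapiens) for inhibition (a higher number here means a weaker inhibitor, a lower number a stronger inhibitor), compound 1 gives > 10000 nM, which is a limit of the assay and not a number.
Compound 2, `CCOC(=O)c1ccc(-c2nn(Cc3ccc(Cl)cc3)c3ccccc23)cc1`. In this assay compound 2 gives > 10000 nM, again only a limit.
Compound 3, `CCOC(=O)c1ccc(-c2nn(Cc3cccc(F)c3)c3ccccc23)cc1`. In this assay compound 3 gives > 10000 nM, also a limit.

Compound 3 therefore stands nowhere on a scale: all three measured compounds sit at the limit of > 10000 nM in this assay, at which 3 of the 3 values shown sit, and none of them separates from the others. The steps among them, a step that the two limits leave unreadable from compound 1 to compound 2, a step that the two limits leave unreadable from compound 1 to compound 3 and a step that the two limits leave unreadable from compound 2 to compound 3, have no readable size because both ends of each are limits.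

Compound 4, `CCOC(=O)c1ccc(-c2nn(Cc3ccc(OC)cc3)c3ccccc23)cc1`, differs from compound 3 by 4-methoxyphenyl in place of 3-fluorophenyl on a saturated chain carbon bound to an aromatic nitrogen. Each measured step changes the same substituted phenyl on that chain carbon, and each left the value at the limit, so none of them gives a direction or a size to lean on. The expectation for compound 4 is accordingly a step of a number no higher from compound 3 to compound 4 (the limit leaves the size open), that is, no change that can be told, with a further limit the most likely outcome. Compound 4 is estimated at 10000 nM, within a range from 3000 nM to 30000 nM.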

Compound 4, half-maximal inhibitory concentration: > 10000 nM
Compound 4: only a limit was reported; the forecaster's own chance of this, stated with the estimate: 80%; the middle value lies on the limit itself.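

In this assay compound 4 gives > 10000 nM, again only a limit. No step from compound 1, compound 2 or compound 3 to compound 4 can be read, since all four compounds sit at the same limit: the limit of > 10000 nM in this assay, at which 4 of the 4 values shown sit.

The compounds shown leave open whether any group on that chain carbon gives a readable value in this assay, and how far such groups would differ.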